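This account rests on a few compounds, and the source may have more. Where it says the series, first, only, none or still open, it means among the compounds named here.

Measured so far in an ADME assay on A-431 cells (Homo sapiens) for cytotoxicity, read by MTT assay, with a stated time of 72 h (a lower number here means a stronger inhibitor of growth, a higher number a weaker inhibitor of growth), are three compounds

compound 1 `CCCCCCCCCCNC(=O)C1C(C(=O)O)[C@@H]2CC[C@H]1O2` at 10000 nM
compound 2 `C=CCNC(=O)C1C(C(=O)O)[C@@H]2CC[C@H]1O2` at 10000 nM
compound 3 `Cn1ccc2cc(CNC(=O)C3C(C(=O)O)[C@@H]4CC[C@H]3O4)ccc21` at 10000 nM

Compound 2 gives 10000 nM in this assay and stands level with compound 1 and compound 3, so nothing separates the three. The unmeasured compound 4 `CCCCNC(=O)C1C(C(=O)O)[C@@H]2CC[C@H]1O2` has propyl in place of vinyl on a saturated chain carbon bound to an amide-type nitrogen, a difference counted as propyl in place of vinyl on a saturated chain carbon bound to an amide-type nitrogen and also readable as allyl to butyl. Compound 1 at 10000 nM and compound 3 at 10000 nM carry other groups in that place and still read the same as compound 2, so no change beyond the scatter is expected in this assay here. The estimate puts no change at the digits printed from compound 2 to compound 4 (within the scatter) within the scatter of repeated measurements. Compound 4 is estimated at 10000 nM with 5000 nM to 20000 nM as the expected range.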

Compound 4, concentration for 50% growth inhibition: 10000 nM
For compound 4 middle estimate and measured number coincide at the digits printed, and the stated range covers the measured number.
By their numbers in this assay, from the lowest: compounds 1, 2, 3 and 4 (each within the scatter of the next).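

In this assay, within the data shown here, putting propyl in place of vinyl on a saturated chain carbon bound to an amide-type nitrogen gives no change at the digits printed from compound 2 to compound 4 (within the scatter) and so is the first direct one-place comparison at this position. It shows that removing the double bond, reading allyl to butyl, leaves the number unmoved. Putting hydrogen in place of hexyl, four bonds along the chain from the amide-type nitrogen, likewise gives no change at the digits printed from compound 1 to compound 4 (within the scatter) in this series of simple chains. Going by these compounds, whether an amine or a carboxylic acid on this chain would shift the reading stays open. Nothing measured here offers an explanation for these flat readings.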